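The source may report more compounds than this note shows. Statements on the series, on what has been measured and on what is new or still open speak of the compounds shown alone.

Values in a functional assay on KB cells (Homo sapiens) for antiproliferative activity, read by sulforhodamine B assay, with a stated time of 3 days; a lower number here means that less compound is needed, a higher number that more compound is needed for the effect:
- compound 1 `CCC1=C(O)c2c(oc(-c3ccc(C(C)C)cc3)cc2=O)C(CC)(CC)C1=O`: 8.13 uM
- compound 2 `CCC1=C(O)c2c(oc(-c3ccccc3C)cc2=O)C(CC)(CC)C1=O`: 40.9 uM
- compound 3 `CCC1=C(O)c2c(oc(-c3ccccc3OC)cc2=O)C(CC)(CC)C1=O`: 40.8 uM

Compound 3 stands level with compound 2, as shown by a 1.0-fold lower number from compound 2 to compound 3 (0.00 log units; within the scatter). Against compound 1, the record shows a 5.0-fold higher number from compound 1 to compound 3 (0.70 log units; beyond the scatter).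

Compound 4 `CCC1=C(O)c2c(oc(-c3ccc(C)c(F)c3)cc2=O)C(CC)(CC)C1=O` has 3-fluoro-4-methylphenyl in place of 2-methoxyphenyl on an aromatic carbon, next to the ring oxygen (3-fluoro-4-methylphenyl in place of 2-methoxyphenyl on an aromatic carbon). The closest guide is the pair of steps away from the 4-isopropylphenyl of compound 1: a 5.0-fold higher number from compound 1 to compound 2 (0.70 log units; beyond the scatter) and a 5.0-fold higher number from compound 1 to compound 3 (0.70 log units; beyond the scatter). Both lead to groups named with a 2-substituent, whereas the group in compound 4 carries its methyl at the 4 position, as compound 1 does. Among the compounds with values here, this rests on compound 1 alone, and no measured compound carries fluoro.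

Within the data shown here, a modest step to a lower number in this assay is therefore expected, slightly smaller than the one separating compound 1 and compound 3. The expected step is a 3.1-fold lower number from compound 3 to compound 4 (0.50 log units; beyond the scatter). For compound 4 the estimate is 13 uM, with an expected range of 5 uM to 35 uM.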

Compound 4, concentration for half-maximal effect: 28.1 uM
Estimate against measurement, compound 4: 2.2-fold (0.33 log units) below, within the range that was stated.
By their numbers in this assay, from the lowest: compound 1; then compounds 4, 3 and 2 (each within the scatter of the next).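

In this assay, replacing the 2-substituted phenyl groups with 3-fluoro-4-methylphenyl gives no readable change, with a 1.5-fold lower number from compound 3 to compound 4 (0.16 log units; within the scatter) and a 1.5-fold lower number from compound 2 to compound 4 (0.16 log units; within the scatter) both lying within the scatter. A methyl named at the 4 position therefore does not by itself bring the number to that of the 4-isopropylphenyl group: a 3.5-fold higher number from compound 1 to compound 4 (0.54 log units; beyond the scatter) leaves compound 1 apart from the other three compounds. Nothing at hand accounts for this gap.

The compounds shown leave open whether plain 4-methylphenyl would stand with compound 4 or nearer compound 1, so the contributions of the fluoro and the methyl cannot be separated. Also open, going by these compounds, is how this position would read with an amine or a carboxylic acid on the phenyl ring, or with a longer chain such as tert-butyl at the 4 position.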